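Shifting a Methoxy Group on the Ring Nitrogen Aryl

A few compounds are considered here, and "the series" means these few. Any claim that something is new, unique, unknown or untested is made for them only; others in the source may bear on it.

Three compounds share one core, a five-membered ring holding a sulfur and an amide-type nitrogen, and differ only in the aryl group on that nitrogen. In a functional assay on U2OS cells (Homo sapiens) for inhibition, read by CCK-8 assay, with a stated time of 72 h, tested at 1 uM (on this read-out lower numbers stand for less inhibition and higher numbers for more inhibition at the one concentration tested (going by the name of the read-out)), compound 1 `COc1ccc(F)cc1N1C(=O)CSC1c1cccc(C(=O)NCCCCc2ccccc2)c1` gives 32%. In this assay compound 2 `O=C(NCCCCc1ccccc1)c1cccc(C2SCC(=O)N2c2ccccc2)c1` gives 68%, and compound 3 `COc1cccc(OC)c1N1C(=O)CSC1c1cccc(C(=O)NCCCCc2ccccc2)c1` gives 41%. Compound 3 thus stands second of the three: compound 1 lies close to it, within the scatter, while compound 2 lies clearly above it.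

The measured steps show a number 36 percentage points higher from compound 1 to compound 2 (beyond the scatter), a number 27 percentage points lower from compound 2 to compound 3 (beyond the scatter), and a number 9 percentage points higher from compound 1 to compound 3 (within the scatter). Both substituted aryl groups therefore sit well below plain phenyl, and the two of them are not separated from each other.

Compound 4 `COc1ccc(N2C(=O)CSC2c2cccc(C(=O)NCCCCc3ccccc3)c2)c(OC)c1` differs from compound 3 by 2,4-dimethoxyphenyl in place of 2,6-dimethoxyphenyl on an amide-type nitrogen in a ring. Among the compounds with values here, no measured step exchanges one dimethoxyphenyl for another, so the nearest guide is that compound 1 and compound 3 both carry substituted aryl groups and give similar values. Compound 4 is therefore expected to stay close to compound 3, with an estimated step of a number 1 percentage points lower from compound 3 to compound 4 (within the scatter) in this assay, not beyond the scatter. Compound 4 is estimated at 40% in this assay, with a likely range from 25% to 58%.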

Compound 4, a percentage reported as inhibition, at one concentration (the size of the read-out at that concentration, not a potency): 37%
Compound 4: the middle estimate sits 3 percentage points above what was measured; low and high end bracket the measured number.
By their numbers in this assay, from the lowest: compounds 1, 4 and 3 (each within the scatter of the next); then compound 2.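

Moving one methoxy group, so that 2,4-dimethoxyphenyl replaces 2,6-dimethoxyphenyl with the same atoms joined differently, gives a number 4 percentage points lower from compound 3 to compound 4 (within the scatter) in this assay and so leaves the two arrangements on the amide-type nitrogen indistinguishable. The new compound also shows a number 31 percentage points lower from compound 2 to compound 4 (beyond the scatter) and a number 5 percentage points higher from compound 1 to compound 4 (within the scatter) in this read-out, so all three substituted aryl groups, including the one with fluorine, now form a single group clearly below plain phenyl, and the placing of the methoxy groups makes no visible difference among these compounds. Nothing available explains why these substituted aryl groups fall below phenyl.

What remains open is whether a single methoxy group on the phenyl, or a lone fluorine, would already bring the number down to this level, or whether it takes the combinations shown here. From the compounds shown here alone, it is also open how a phenyl carrying an amine or a carboxylic acid would behave on this nitrogen, or how a longer chain in place of the aryl group would compare with plain phenyl.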